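Series notes: dimethoxyphenyl in place of fluorophenyl

The source may report more compounds than this note shows. Statements on the series, on what has been measured and on what is new or still open speak of the compounds shown alone.

Two compounds of the shared core have been run in a functional assay on MCF7 cells (Homo sapiens) for antiproliferative activity, read by MTT assay, with a stated time of 24 h; on this read-out higher numbers stand for weaker inhibition and lower numbers for stronger inhibition. Compound 1 `COc1ccc(C2CC(c3ccccc3)=NN2c2ccc(-c3ccccc3)nn2)c(OC)c1` returns only a limit there, > 100000 nM, and so carries no number. Among the measured compounds shown here, compound 2 `COc1ccc(C2=NN(c3ccc(-c4ccccc4)nn3)C(c3ccc(F)cc3)C2)cc1` gives 20000 nM in this assay, the sole number on record, so compound 2 is the one measured point from which the series can be judged; the limit of > 100000 nM in this assay, at which 1 of the 2 values shown sits, marks where compound 1 sits.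

Compound 3 `COc1ccc(C2=NN(c3ccc(-c4ccccc4)nn3)C(c3ccc(OC)cc3OC)C2)cc1` is not yet measured. It differs from compound 2 in one place: 2,4-dimethoxyphenyl in place of 4-fluorophenyl on a saturated ring carbon. Compound 1 also carries a 2,4-dimethoxyphenyl group on a saturated ring carbon and sits at the limit, whereas compound 2, with 4-fluorophenyl on a saturated ring carbon, gives a number. For the measured compounds named here, no measured step between two numbered compounds exists to fix the size of this change. The expected step in this assay is a 2.5-fold higher number from compound 2 to compound 3 (0.40 log units; beyond the scatter), toward weaker inhibition and beyond the scatter, though uncertain. Compound 3 is therefore estimated at 50000 nM in this assay, within 15000 nM to 150000 nM, with a real chance that only a limit is returned.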

Compound 3, half-maximal inhibitory concentration: 100000 nM
Estimate against measurement, compound 3: 2.0-fold (0.30 log units) below, within the range that was stated.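

In this assay the saturated ring carbon next to the ring nitrogen now has its first measured step: 2,4-dimethoxyphenyl in place of 4-fluorophenyl gives a 5.0-fold higher number from compound 2 to compound 3 (0.70 log units; beyond the scatter), so the aryl group at this position does affect the read-out, and here the change goes toward weaker inhibition. Compound 3 still returns a number, 100000 nM. Methoxy in place of hydrogen on an aromatic carbon gives a number no higher from compound 1 to compound 3 (the limit leaves the size open), and the size of this step cannot be read. Compound 1 returns only a limit: the limit of > 100000 nM in this assay, at which 1 of the 3 values shown sits.

The compounds shown do not separate the contributions of the two methoxy groups, so a phenyl carrying a single methoxy group at this position remains an open case. Only fluorine and methoxy substituents are shown on this aryl ring, which leaves open how an amine or a carboxylic acid in their place would read in this assay.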